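The source may report more compounds than this note shows. Statements on the series, on what has been measured and on what is new or still open speak of the compounds shown alone.

In a functional assay, read by spectrophotometry, with a stated time of 30 min (a lower number here means a stronger inhibitor, a higher number a weaker inhibitor), compound 1 (`CC(C)(C)c1cc(/C=C/C(=O)NCC2CCN(Cc3ccccc3)CC2)cc(C(C)(C)C)c1O`) gives 75600 nM and compound 2 (`COc1ccc(CN2CCC(CCNC(=O)/C=C/c3cc(C(C)(C)C)c(O)c(C(C)(C)C)c3)CC2)cc1`) gives 61200 nM as its half-maximal inhibitory concentration, two values within the usual scatter of each other, so compound 2 stands level with compound 1. Compound 3 (`CC(C)(C)c1cc(/C=C/C(=O)NCCC2CCN(Cc3cccc(F)c3)CC2)cc(C(C)(C)C)c1O`) differs from compound 2 in one place, by 3-fluorophenyl in place of 4-methoxyphenyl on a saturated chain carbon bound to an amine nitrogen in a ring on a saturated chain carbon bound to an amine nitrogen in a ring. Going by the values given here, no step between measured compounds tests this change, so in this assay no shift beyond the scatter is expected in either direction. The expected step is a 1.0-fold lower number from compound 2 to compound 3 (0.01 log units; within the scatter) in this estimate. The estimate for compound 3 is 60000 nM with an expected range from 28000 nM to 110000 nM for the measurement to come.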

Compound 3, half-maximal inhibitory concentration: 55200 nM
Compound 3: middle estimate off by 1.1-fold (0.04 log units), on the high side; low and high end bracket the measured number.
By their numbers in this assay, from the lowest: compounds 3, 2 and 1 (each within the scatter of the next).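

In this assay, going by these compounds alone, this position on a saturated chain carbon bound to an amine nitrogen in a ring is tested for the first time, and 3-fluorophenyl in place of 4-methoxyphenyl gives a 1.1-fold lower number from compound 2 to compound 3 (0.04 log units; within the scatter). The two groups therefore read alike here, even though the change removes the single hydrogen-bond acceptor of the group that leaves. Nothing measured here bears on this result. Still open, from the compounds shown here alone, is whether an amine or a carboxylic acid on this phenyl ring, or a longer chain in place of the benzyl link, would move the number beyond the scatter.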